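The source may report more compounds than this note shows. Statements on the series, on what has been measured and on what is new or still open speak of the compounds shown alone.

Of the compounds shown here, three built on a shared core have so far been tested in an ADME assay on MRC5 cells (Homo sapiens) for inhibition, with a stated time of 72 h; on this read-out lower numbers stand for an effect already at smaller amounts and higher numbers for an effect only at larger amounts of compound. Compound 1 `CO[C@H]1CC[C@H](NC(=O)c2n[nH]cc2NC(=O)c2ccc(F)cc2F)CC1` gives 11000 nM in this assay, the lowest of the two numbers recorded. Compound 3 `COc1cccc(OC)c1C(=O)Nc1c[nH]nc1C(=O)N[C@H]1CC[C@H](OC)CC1` gives 31000 nM in this assay, a gap from compound 1 that lies beyond the usual scatter of repeated measurements. Compound 2 `COc1cccc(OC)c1C(=O)Nc1c[nH]nc1C(=O)NC1CCN(C(=O)OC(C)(C)C)CC1` reaches only a limit in this assay, > 50000 nM, so no number is known for it; this is the limit of > 50000 nM in this assay, at which 1 of the 3 values shown sits.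

The next compound, compound 4 `CO[C@H]1CC[C@H](NC(=O)c2n[nH]cc2NC(=O)c2ccccc2)CC1`, differs from compound 1 in one place: phenyl in place of 2,4-difluorophenyl on a carbonyl carbon. Among the compounds with values here, no pair among the measured compounds shows this change, so its effect in this assay can only be guessed from the single starting value of compound 1. A change of this kind, confined to a single aromatic ring on a carbonyl carbon, is expected to move the number little, if at all beyond the scatter, with a slight lean toward a higher number. The author therefore expects compound 4 to give about 15000 nM in this assay, within a range from 6000 nM to 40000 nM. This estimate means a step of a 1.4-fold higher number from compound 1 to compound 4 (0.13 log units; within the scatter), expected to stay close to the scatter of the method.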

Compound 4, half-maximal effective concentration: 800 nM
For compound 4 the middle estimate is 19-fold (1.27 log units) above the measured one; the whole stated range lies above it.
By their numbers in this assay, from the lowest: compound 4; then compound 1; then compound 3. At a limit, above all of these: compound 2.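

In this assay, within the data shown here, the exchange of 2,4-difluorophenyl for phenyl on a carbonyl carbon gives a 14-fold lower number from compound 1 to compound 4 (1.14 log units; beyond the scatter), the first step in this set between compounds that differ in one place. It shows that this position is not silent on this read-out: with the rest of the molecule unchanged and an unsubstituted phenyl in place of the 2,4-difluorophenyl, the effect appears at much smaller amounts of compound, so the fluorine substituents of compound 1 are tied to the higher number. The values shown give no measured property that would explain this step, so its cause remains unknown.

The compounds shown leave open whether a phenyl bearing a single fluorine would stand with compound 1 or compound 4, and whether a chlorine, a methyl, a methoxy group, a nitrile or an amine on this ring would also give a number far from that of compound 4. They also leave open whether the same exchange would give a step of similar size with a group other than the methoxycyclohexyl group of compound 4 on the other amide.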